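Enlarging the branched alkyl group: compound 2 to compound 4

The compounds below may be only part of what the source reports. "The series", "measured", "known", "first", "only" and "open" are said of these compounds alone.

Compound 1 `CCC(CC)(CC)/N=C(\NC#N)Nc1cc(Cl)cc(Cl)c1`: > 1 uM, a limit of the assay
Compound 2 `CCC(C)(C)/N=C(\NC#N)Nc1cc(Cl)cc(C#N)c1`: 0.02 uM
Compound 3 `CCC(C)(C)/N=C(\NC#N)Nc1cc(Br)cc(C#N)c1`: 0.011 uM
Compound 4 `CCC(CC)(CC)/N=C(\NC#N)Nc1cc(Cl)cc(C#N)c1`: not yet measured

In a functional assay with Cavia porcellus as the target (on this read-out lower numbers stand for an effect already at smaller amounts and higher numbers for an effect only at larger amounts of compound), compound 2 gives 0.02 uM, the highest of the two numbers shown, and compound 3 gives 0.011 uM. The step of a 1.8-fold lower number from compound 2 to compound 3 (0.26 log units; within the scatter) lies within the scatter. For compound 1 the read-out is a limit, > 1 uM, and not a number (the limit of > 1 uM in this assay, at which 1 of the 3 values shown sits). Compound 4 differs from compound 2 by 1,1-diethylpropyl in place of 1,1-dimethylpropyl on a double-bonded nitrogen. No measured step concerns this place: the one step shown, a 1.8-fold lower number from compound 2 to compound 3 (0.26 log units; within the scatter), alters a different part of the molecule and says nothing about the alkyl group. Compound 1 also carries 1,1-diethylpropyl and gives only a limit, but it differs from compound 2 in more than one place, so it cannot measure this step. Compound 4 is therefore expected near 0.1 uM, between 0.02 uM and 1 uM. The expected step is a 5.0-fold higher number from compound 2 to compound 4 (0.70 log units; beyond the scatter), toward a higher number with wide uncertainty.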

Compound 4, concentration for half-maximal effect: > 1 uM
Compound 4 gave a limit, no number; the forecaster's own chance of this, stated with the estimate: 25%; middle value at least 10-fold (1.00 log units) from the limit.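

Putting 1,1-diethylpropyl in place of 1,1-dimethylpropyl on the double-bonded nitrogen gives an at least 50-fold higher number from compound 2 to compound 4 (1.69 log units; beyond the scatter), the first single change shown at this position, and it is a large loss of effect. Compound 1 and compound 4 both stand at one limit, so the step between them cannot be read: the limit of > 1 uM in this assay, at which 2 of the 4 values shown sit.

The compounds shown leave open how a tert-butyl or a 1-ethyl-1-methylpropyl group would read at this position. They also leave open whether a cyclohexyl ring would be met with the same loss.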